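Second amine on the chain of compound 1

A few compounds are considered here, and "the series" means these few. Any claim that something is new, unique, unknown or untested is made for them only; others in the source may bear on it.

Measured so far:
Compound 1 `CCCCCCCCCCc1ccc(-c2noc(CCCN)n2)cc1`: 67%
Compound 2 `CCCCCCCCCCc1ccc(-c2noc(CCCN(C)C)n2)cc1`: 8%
Compound 3 `CCCCCCCCCCc1ccc(-c2noc([C@@H]3CC[C@H](N)C3)n2)cc1`: 38%

In an assay on HeLa cells for inhibition of sphingosine-1-phosphate transporter SPNS2 (Mus musculus), read by LC-MS, tested at 2 uM (a lower number here means less inhibition, a higher number more inhibition at the concentration tested (going by the name of the read-out)), compound 1 gives 67%, the highest of the three numbers; compound 3 follows at 38% and compound 2 lies furthest away at 8%. Compound 4 `CCCCCCCCCCc1ccc(-c2noc([C@@H](N)CCCN)n2)cc1` has not yet been measured. It differs from compound 1 in one place: 1,4-diaminobutyl in place of 3-aminopropyl on an aromatic carbon. Both known steps from compound 1 lower the number: a number 59 percentage points lower from compound 1 to compound 2 (beyond the scatter), a large drop on changing the amine itself, and a number 29 percentage points lower from compound 1 to compound 3 (beyond the scatter), a modest drop on moving the amine onto a ring. Neither step introduces a second amine, so the change in compound 4 is only loosely covered; the primary amine is kept, which argues for a smaller loss than in compound 2. Compound 4 is expected to give 55%, between 25% and 80%, a step of a number 12 percentage points lower from compound 1 to compound 4 (beyond the scatter).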

Compound 4, a percentage reported as inhibition, at one concentration (the size of the read-out at that concentration, not a potency): 40%
The estimate for compound 4 lay 15 percentage points above the measured number; low and high end bracket the measured number.
By their numbers in this assay, from the lowest: compound 2; then compounds 3 and 4 (each within the scatter of the next); then compound 1.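

On the aromatic carbon of the shared core, 1,4-diaminobutyl, with its second amine and a defined stereocentre, does not keep the level of 3-aminopropyl, giving a number 27 percentage points lower from compound 1 to compound 4 (beyond the scatter) in this assay. Against 3-aminocyclopentyl the change gives a number 2 percentage points higher from compound 3 to compound 4 (within the scatter), and against 3-(dimethylamino)propyl it gives a number 32 percentage points higher from compound 2 to compound 4 (beyond the scatter), so this diamine matches neither extreme of the earlier series. No measurement at hand accounts for these steps. Open, as far as these compounds go, is whether the second amine or the branching of the chain drives the loss, and whether a hydroxyl group or a carboxylic acid in its place would behave alike.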